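Methylsulfonyl in place of hydroxy: notes toward compound 4

The source may hold more compounds than are shown below. What is called first, only, known or untested is meant among the compounds shown, and "the series" means these compounds.

Of the compounds shown here, three so far have numbers in a functional assay on Huh-7 cells (Homo sapiens) for cytotoxicity, with a stated time of 48 h (a lower number here means a stronger inhibitor, a higher number a weaker inhibitor), to compare. Compound 1 `N#Cc1ccc(-c2cncc(-c3cc4ccc(O)cc4[nH]3)c2)cc1` gives 1500 nM here. Compound 2 `CS(=O)(=O)c1ccc(-c2cncc(-c3cc4ccc(O)cc4[nH]3)c2)cc1` gives 3000 nM in the same read-out. Compound 3 `Oc1ccc(-c2cncc(-c3cc4ccc(O)cc4[nH]3)n2)cc1` gives 5000 nM and so stands within the scatter of compound 2, while its number lies beyond the scatter on the higher side of compound 1.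

The next structure is compound 4 `CS(=O)(=O)c1ccc(-c2cncc(-c3cc4ccc(O)cc4[nH]3)n2)cc1` which departs from compound 3 by one change: methylsulfonyl in place of hydroxy on an aromatic carbon that is, methylsulfonyl in place of hydroxy on an aromatic carbon, para to a large group.

Among the measured compounds shown here, no measured step makes this exact replacement. The closest is a 2.0-fold higher number from compound 1 to compound 2 (0.30 log units; within the scatter) which brings in methylsulfonyl in place of cyano on the core of compound 1 and stays within the scatter. The expectation therefore rests on that small step and on compound 2 at 3000 nM which carries the methylsulfonyl that compound 4 would carry, though on a different core.

No step beyond the scatter is expected, and the direction is not firmly indicated. The expected step in this assay is a 1.4-fold lower number from compound 3 to compound 4 (0.15 log units; within the scatter) and would remain within the scatter. For compound 4 the estimated value is 3500 nM with 1300 nM to 10000 nM as the expected range.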

Compound 4, half-maximal inhibitory concentration: 7000 nM
Compound 4: the middle estimate sits 2.0-fold (0.30 log units) below what was measured; low and high end bracket the measured number.
By their numbers in this assay, from the lowest: compounds 1, 2, 3 and 4 (each within the scatter of the next, the first and the last beyond it).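

Among the compounds shown here, on the core of compound 3, methylsulfonyl in place of hydroxy on an aromatic carbon para to a large group gives a 1.4-fold higher number from compound 3 to compound 4 (0.15 log units; within the scatter) in this assay, the first direct reading of this replacement. At this position, the hydroxy, with its hydrogen-bond donor and 1 heavy atom, can give way to a methylsulfonyl with 4 heavy atoms and 0 hydrogen-bond donors, without a step beyond the scatter in this read-out, so the two groups cannot be told apart here on the strength of these two compounds alone. Nothing measured accompanies this result that could account for the step, which therefore stands as an observation only.

On these data alone, whether this tolerance extends to other groups at the same position remains open, since an amine, a carboxylic acid or a longer chain such as ethylsulfonyl could separate from hydroxy in a way methylsulfonyl does not. As far as these compounds go, it also remains open whether the same replacement would read alike on the core of compound 1, and whether a nitrile on the core of compound 3 would fall within the scatter of compound 3 and compound 4.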